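The source may report more compounds than this note shows. Statements on the series, on what has been measured and on what is new or still open speak of the compounds shown alone.

Compound 1 `CC(C)Oc1cc(Oc2ccc(S(C)(=O)=O)cc2)cc(-c2ccnc(=O)[nH]2)c1` in an ADME assay on MDCK-II cells (Canis lupus familiaris) for permeability (on this read-out lower numbers stand for lower permeability and higher numbers for higher permeability), gives "not determined" (no result reported); for this compound no number is available. Going by the values given here, a related compound, compound 2 `CCS(=O)(=O)c1ccc(Oc2cc(O[C@@H](C)CO)cc(-c3nccc(=O)[nH]3)c2)cc1`, was measured in this assay and gives 2.8 10^-6 cm/s, and this is the only number that anchors the series. Compound 3 `COc1cnc(-c2cc(Oc3ccc(S(C)(=O)=O)cc3)cc(OC(C)C)c2)[nH]c1=O` has not yet been measured. Compound 3 differs from compound 1 in one place: a group of 9 heavy atoms (5 carbon, 2 nitrogen, 2 oxygen; one six-membered aromatic ring with 2 hetero atoms) in place of a group of 7 heavy atoms (4 carbon, 2 nitrogen, 1 oxygen; one six-membered aromatic ring with 2 hetero atoms), on an aromatic carbon. The change sits on an aromatic carbon of the six-membered all-carbon ring, meta to a large group and meta to an isopropoxy group. Among the compounds with values here, with no measured pair of this kind available, the step from compound 1 to compound 3 in this assay cannot be drawn from data; the swap is modest, so any shift is expected to stay within the usual scatter or just beyond it. For compound 3 the permeability in this assay is estimated at 5 10^-6 cm/s, with a likely range from 1.5 10^-6 cm/s to 15 10^-6 cm/s.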

Compound 3, apparent permeability: 3.9 10^-6 cm/s
Compound 3: the middle estimate sits 1.3-fold (0.11 log units) above what was measured; the range from low to high includes it.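

Going by these compounds alone, no step from compound 1 to compound 3 can be read from these results in this assay. The compounds shown leave open what swapping the group on the shared core does to this read-out. No evidence shown bears on the value of compound 3.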